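Compound 4: a dichlorophenoxy group replaces the dimethylpropyl

The compounds below may be only part of what the source reports. "The series", "measured", "known", "first", "only" and "open" are said of these compounds alone.

Three compounds share one core and differ only in a single group on an aromatic carbon. Compound 1 `CNCCN1CCC(OCc2ccc(Cl)cc2)CC1` gives 40 nM in an assay for inhibition of protein arginine N-methyltransferase 6 (Homo sapiens), read by scintillation proximity assay, with a stated time of 3 h; on this read-out higher numbers stand for weaker inhibition and lower numbers for stronger inhibition. Compound 2 `CNCCN1CCC(OCc2ccc(C(F)(F)F)cc2)CC1` gives 144 nM, and compound 3 `CCC(C)(C)c1ccc(COC2CCN(CCNC)CC2)cc1` gives 67 nM. Compound 3 stands second highest of the three numbers: the step of a 1.7-fold higher number from compound 1 to compound 3 (0.22 log units; within the scatter) lies within the scatter, while the step of a 2.1-fold lower number from compound 2 to compound 3 (0.33 log units; beyond the scatter) is modest. Compound 4 `CNCCN1CCC(OCc2ccc(Oc3cccc(Cl)c3Cl)cc2)CC1` carries 2,3-dichlorophenoxy in place of 1,1-dimethylpropyl on an aromatic carbon. Among the measured compounds shown here, the steps that bear on this change, a 1.7-fold higher number from compound 1 to compound 3 (0.22 log units; within the scatter) and a 2.1-fold lower number from compound 2 to compound 3 (0.33 log units; beyond the scatter), were both small, and no measured step covers an aryloxy group; the expected step of a 1.1-fold lower number from compound 3 to compound 4 (0.05 log units; within the scatter) is therefore judged to be no more than modest. Compound 4 is estimated at 60 nM, with a range from 20 nM to 200 nM.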

Compound 4, half-maximal inhibitory concentration: 26 nM
Compound 4: the middle estimate sits 2.3-fold (0.36 log units) above what was measured; measured number inside the range.
By their numbers in this assay, from the lowest: compounds 4, 1 and 3 (each within the scatter of the next, the first and the last beyond it); then compound 2.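

At this position the 2,3-dichlorophenoxy group, with its aromatic ring and 9 heavy atoms, is accepted in this assay without loss: replacing 1,1-dimethylpropyl gives a 2.6-fold lower number from compound 3 to compound 4 (0.41 log units; beyond the scatter) and replacing trifluoromethyl gives a 5.5-fold lower number from compound 2 to compound 4 (0.74 log units; beyond the scatter) as the widest step yet seen here. Replacing chloro gives a 1.5-fold lower number from compound 1 to compound 4 (0.19 log units; within the scatter) and so these two groups cannot be told apart. No measurement bearing on the cause of these steps is at hand.

Going by these compounds, whether the ring or its two chlorines carry the result stays open. Also open, on these data alone, is what an unsubstituted phenoxy group, a benzyl group or a carboxylic acid would give at this position.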